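Swapping the carbonyl substituent on a piperidine carbamate

This account rests on a few compounds, and the source may have more. Where it says the series, first, only, none or still open, it means among the compounds named here.

Measured so far in a functional assay on isolated protein for inhibition of Glucose-dependent insulinotropic receptor (Homo sapiens), read by HTRF and cAMP accumulation; on this read-out lower numbers stand for an effect already at smaller amounts and higher numbers for an effect only at larger amounts of compound:
- compound 1 `Cc1nc(S(C)(=O)=O)ccc1Oc1ncnc(OC2CCN(C(=O)OC3COC3)CC2)c1F`: 326 nM
- compound 2 `Cc1nc(S(C)(=O)=O)ccc1Oc1ncnc(OC2CCN(C(=O)SC(C)C)CC2)c1F`: 6.8 nM

For the measured compounds named here, compound 2 carries the lowest of the two numbers so far; its only neighbour, compound 1, sits far higher. Going by the values given here, the single step between them, a 48-fold lower number from compound 1 to compound 2 (1.68 log units; beyond the scatter), shows that the group attached to the carbonyl carbon on the piperidine nitrogen can shift the read-out strongly.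

Compound 3 `Cc1nc(S(C)(=O)=O)ccc1Oc1ncnc(OC2CCN(C(=O)C(C)(F)F)CC2)c1F` takes the same carbonyl carbon and changes it once more: 1,1-difluoroethyl in place of isopropylsulfanyl on a carbonyl carbon. Among the compounds with values here, no measured step covers a fluorinated alkyl group here; the one step available, from compound 1 to compound 2, only tells that this position is sensitive, not in which direction a move away from isopropylsulfanyl leads. Given that compound 2 already holds the lowest number and that replacing its carbonyl substituent has so far been consequential, a moderate rise in the number is expected for compound 3, estimated as a 4.4-fold higher number from compound 2 to compound 3 (0.64 log units; beyond the scatter), with wide uncertainty. The estimate for compound 3 is therefore 30 nM, with a range from 5 nM to 200 nM.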

Compound 3, half-maximal effective concentration: 37 nM
Estimate against measurement, compound 3: 1.2-fold (0.09 log units) below; low and high end bracket the measured number.
By their numbers in this assay, from the lowest: compound 2; then compound 3; then compound 1.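

A carbonyl substituent with neither sulfur nor oxygen attached to the carbonyl carbon can keep much of the low number: in this assay the change to 1,1-difluoroethyl gives a 5.4-fold higher number from compound 2 to compound 3 (0.74 log units; beyond the scatter) and, measured against the other earlier compound, an 8.8-fold lower number from compound 1 to compound 3 (0.95 log units; beyond the scatter) which places compound 3 between the two. The sulfur of isopropylsulfanyl is therefore not required for a number well under that of compound 1, although compound 2 remains the lowest of the three, with both of its steps beyond the usual scatter. Isopropylsulfanyl and 1,1-difluoroethyl also have the same count of heavy atoms yet give clearly different numbers, so that count alone does not set the read-out at this position.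

These three groups cannot separate what the sulfur contributes from what the fluorines contribute, and a plain isopropyl group, a tert-butyl group or an amine such as dimethylamino on the same carbonyl carbon would help to show which atoms matter. No independent measurement is available here to explain why the numbers differ.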